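Methoxycyclobutyl for cyclopropyl: a step repeated on a second core

This account rests on a few compounds, and the source may have more. Where it says the series, first, only, none or still open, it means among the compounds named here.

Three compounds have been measured in an ADME assay on the whole organism (Canis lupus familiaris, strain Beagle) for metabolic stability; on this read-out lower numbers stand for slow clearance and higher numbers for fast clearance:
Compound 1 `CCn1c(-c2cnc(C)nc2)nc2c(N[C@H]3CCN(C(=O)[C@H]4C[C@@H](OC)C4)C3)ncnc21` gives 13 mL/min/kg.
Compound 2 `CCn1c(-c2cnc(C)nc2)nc2c(O[C@H]3CCN(C(=O)C4CC4)C3)ncnc21` gives 7 mL/min/kg.
Compound 3 `CCn1c(-c2cnc(C)nc2)nc2c(N[C@H]3CCN(C(=O)C4CC4)C3)ncnc21` gives 6.2 mL/min/kg.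

Compound 1 and compound 3 share a core and differ by one change, (3-methoxycyclobutyl in place of cyclopropyl on a carbonyl carbon). That single change produced a 2.1-fold higher number from compound 3 to compound 1 (0.32 log units; beyond the scatter). Compound 2 sits on a different core; the difference between the two cores is not broken down here. Compound 4 `CCn1c(-c2cnc(C)nc2)nc2c(O[C@H]3CCN(C(=O)[C@H]4C[C@@H](OC)C4)C3)ncnc21` has not yet been measured, and it relates to compound 2 exactly as compound 1 relates to compound 3: 3-methoxycyclobutyl in place of cyclopropyl on a carbonyl carbon. The surroundings of the change are described in the same words for both pairs, so this is the same change made a second time.

On that basis the step from compound 2 to compound 4 in this assay is expected to be of similar size to the earlier one, a 2.0-fold higher number from compound 2 to compound 4 (0.30 log units; within the scatter), resting on a 2.1-fold higher number from compound 3 to compound 1 (0.32 log units; beyond the scatter). Compound 4 is therefore estimated at 14 mL/min/kg, most likely between 8 mL/min/kg and 25 mL/min/kg.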

Compound 4, clearance: 3.3 mL/min/kg
The estimate for compound 4 lay 4.2-fold (0.63 log units) above the measured number; measured number below the stated range.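

In this assay, the same swap of cyclopropyl for 3-methoxycyclobutyl gave a 2.1-fold lower number from compound 2 to compound 4 (0.33 log units; beyond the scatter), the opposite direction to the earlier step. The two results do not agree: the same change on two cores in this assay, a 2.1-fold higher number (0.32 log units; beyond the scatter) from compound 3 to compound 1 and a 2.1-fold lower number (0.33 log units; beyond the scatter) from compound 2 to compound 4, 4.4-fold (0.65 log units) apart, beyond the scatter of two such steps. On these two cores, then, a step measured on one could not be carried over to the other, though the two pairs do not show which difference between the cores goes with the reversal, or whether the split would hold on any further core.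

As far as these compounds go, it stays open whether a plain cyclobutyl, without the methoxy group, would split the two cores in the same way. The same question stands for a longer chain on the carbonyl carbon.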